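This account rests on a few compounds, and the source may have more. Where it says the series, first, only, none or still open, it means among the compounds named here.

Compound 1 `COC(=O)c1ccc(CCCCCCC(=O)c2ncc(-c3ccccn3)o2)cc1` sets the reference point: in an assay for inhibition of Fatty-acid amide hydrolase 1 (Rattus norvegicus) (a higher number here means a weaker inhibitor, a lower number a stronger inhibitor), compound 1 gives 1.5 nM. Compound 2 `COC(=O)CCC(=O)c1ncc(-c2ccccn2)o1` shares the same core with a much shorter chain ending in methoxycarbonyl. In this assay compound 2 gives > 100000 nM, which is a limit of the assay and not a number, so compound 2 stands only at the weak end of what can be read (the limit of > 100000 nM in this assay, at which 1 of the 2 values shown sits). Compound 3 `COC(=O)CCCC(=O)c1ncc(-c2ccccn2)o1` differs from compound 2 by a single change: (methoxycarbonyl)methyl in place of methoxycarbonyl on a saturated chain carbon, two bonds along the chain from a carbonyl carbon. For the measured compounds named here, no measured step of this kind exists here, so the step from compound 2 to compound 3 is expected to be a number no higher from compound 2 to compound 3 (the limit leaves the size open), a change not clearly beyond the usual scatter. Compound 3 is therefore estimated at 100000 nM, with a likely range from 20000 nM to 300000 nM.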

Compound 3, inhibition constant: 7000 nM
Compound 3: middle estimate off by 14-fold (1.15 log units), on the high side, and the stated range ends above it.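

Replacing methoxycarbonyl with (methoxycarbonyl)methyl on a saturated chain carbon, two bonds along the chain from a carbonyl carbon, gives an at least 14-fold lower number from compound 2 to compound 3 (1.15 log units; beyond the scatter) in this assay. This position therefore responds to even a small change in chain length. Compound 2 stands at a limit of the assay and not at a number, so the true size of this step stays open: the limit of > 100000 nM in this assay, at which 1 of the 3 values shown sits.

Going by these compounds, whether 2-(methoxycarbonyl)ethyl in the same place would lower the number further remains open. So does whether a carboxylic acid at the chain end would behave like methoxycarbonyl.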